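Pyrazolyl in Place of Dichlorophenyl: A Flat Step Expected

The source may report more compounds than this note shows. Statements on the series, on what has been measured and on what is new or still open speak of the compounds shown alone.

Measured so far in an assay on CHO cells for displacement of a labelled ligand from adenosine receptor A1 (Homo sapiens), read by scintillation counting, tested at 10 uM; on this read-out lower numbers stand for less inhibition and higher numbers for more inhibition at the one concentration tested (going by the name of the read-out):
compound 1 `CC(C)(C)Cc1c(-c2ccncc2)sc(N)c1C(=O)c1ccc(Cl)cc1` gives 1%
compound 2 `CC(C)(C)Cc1c(-c2cccc(F)c2F)sc(N)c1C(=O)c1ccc(Cl)cc1` gives 1%
compound 3 `CC(C)(C)Cc1c(-c2ccc(Cl)c(Cl)c2)sc(N)c1C(=O)c1ccc(Cl)cc1` gives 1%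

Compound 3 stands level with the other two: the steps of no change at the digits printed from compound 1 to compound 3 (within the scatter) and no change at the digits printed from compound 2 to compound 3 (within the scatter) lie within the scatter, as does no change at the digits printed from compound 1 to compound 2 (within the scatter). Compound 4 `CC(C)(C)Cc1c(-c2cn[nH]c2)sc(N)c1C(=O)c1ccc(Cl)cc1` differs from compound 3 by 1H-pyrazol-4-yl in place of 3,4-dichlorophenyl on an aromatic carbon. All three measured steps bear on this change, since each of them also exchanged the aromatic group at the same place, and none of them moved the read-out. The expected step is therefore a number 1 percentage points higher from compound 3 to compound 4 (within the scatter), none beyond the scatter. For compound 4 the estimate is 2%, expected to fall between -8% and 12%.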

Compound 4, a percentage reported as inhibition, at one concentration (the size of the read-out at that concentration, not a potency): 1%
For compound 4 the middle estimate is 1 percentage points above the measured one; the measured number falls inside the stated range.
By their numbers in this assay, from the lowest: compounds 1, 2, 3 and 4 (each within the scatter of the next).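

At this place, on an aromatic carbon next to the ring sulfur, this assay shows no change at the digits printed from compound 3 to compound 4 (within the scatter), alongside no change at the digits printed from compound 2 to compound 4 (within the scatter) and no change at the digits printed from compound 1 to compound 4 (within the scatter). The flat picture therefore extends beyond six-membered aromatic rings to a five-membered aromatic ring with 2 hetero atoms, which also brings 1 hydrogen-bond donor. No evidence is available to explain this flat result.

The compounds shown leave open whether a non-aromatic group here, such as morpholine or a carboxylic acid, would move this read-out. They also leave open whether replacing the neopentyl group with a methyl group would do so.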